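The source may report more compounds than this note shows. Statements on the series, on what has been measured and on what is new or still open speak of the compounds shown alone.

Of the compounds shown here, three have been measured in a functional assay on cells for positive allosteric modulation of metabotropic glutamate receptor 2 (Homo sapiens), read by fluorescence and calcium flux, with a stated time of 30 min; on this read-out higher numbers stand for an effect only at larger amounts of compound and lower numbers for an effect already at smaller amounts. Compound 1, with the structure `Fc1ccc(Cn2nnc3c(Br)cccc32)cc1`, gives 15 nM in this assay. Compound 2, with the structure `Clc1ccc(Cn2nnc3c(Br)cccc32)cc1`, gives 17 nM in this assay. Compound 3, with the structure `Clc1cc(Br)c2nnn(CC3CC3)c2c1`, gives 60 nM in this assay, a higher number than either compound 1 or compound 2 by an amount beyond the usual scatter.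

Compound 1 and compound 2 differ in one place: fluoro in place of chloro on an aromatic carbon. This change made a 1.1-fold lower number from compound 2 to compound 1 (0.05 log units; within the scatter), so the two numbers cannot be told apart. Compound 3 is built on a different core, and the difference between the two cores is not broken down here.

Compound 4, with the structure `Fc1cc(Br)c2nnn(CC3CC3)c2c1`, has not yet been measured. It differs from compound 3 in one place: fluoro in place of chloro on an aromatic carbon. Within the data shown here, this is the same kind of change as the one from compound 2 to compound 1, but the surroundings are not the same. In compound 1 the fluoro sits on a six-membered aromatic ring of carbon only, para to a large group; in compound 4 it sits on a six-membered aromatic ring of carbon only that is part of a fused or bridged system of two rings, meta to a bromo group, meta to a fused ring and para to a fused ring.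

Because the same kind of change gave a 1.1-fold lower number from compound 2 to compound 1 (0.05 log units; within the scatter), the expected step here is a 1.1-fold lower number from compound 3 to compound 4 (0.04 log units; within the scatter). Compound 4 is therefore estimated to give about 55 nM in this assay, most likely between 25 nM and 130 nM.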

Compound 4, half-maximal effective concentration: 70 nM
For compound 4 the middle estimate is 1.3-fold (0.10 log units) below the measured one; the range from low to high includes it.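

Swapping chloro for fluoro on the core of compound 3 gave a 1.2-fold higher number from compound 3 to compound 4 (0.07 log units; within the scatter) in this assay, so the two numbers cannot be told apart. The same swap on the other core also left the numbers indistinguishable, and the two results agree: the same change on two cores in this assay, a 1.1-fold lower number (0.05 log units; within the scatter) from compound 2 to compound 1 and a 1.2-fold higher number (0.07 log units; within the scatter) from compound 3 to compound 4, 1.3-fold (0.12 log units) apart, within the scatter of two such steps

So in this small set, the swap from chloro to fluoro carries over from one core to the other, with no measurable effect on either. This rests on just two pairs, however, and the halogen sits in different surroundings in each, so it does not show that the two halogens can be exchanged freely on other cores or at other places on the ring. Nor does it say why the numbers stay level, and since both steps lie within the scatter, a small real effect in either direction cannot be ruled out.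

Going by these compounds, only chloro and fluoro appear at this place, so it remains open how a larger or differently built group, such as a nitrile, a methoxy group or an amine, would read in this assay. All four compounds also keep their bromo group, which leaves open what a methyl group or a carboxylic acid in its place would do.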